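A few compounds are considered here, and "the series" means these few. Any claim that something is new, unique, unknown or untested is made for them only; others in the source may bear on it.

Measured so far in a functional assay on the whole organism (spleen, spleen) with Rattus norvegicus as the target; on this read-out higher numbers stand for an effect only at larger amounts of compound and lower numbers for an effect already at smaller amounts:
compound 1, `CCCCCCCCc1ccc(CCC(N)CO)cc1` — in this assay compound 1 gives > 10 mg/kg, a limit of the assay rather than a number.
compound 2, `CCCCCCCOc1ccc(CCC(N)(CO)C(C)C)cc1` — in this assay compound 2 gives 2.7 mg/kg.

Compound 2 thus carries the only number shown; the other entry is a limit, (the limit of > 10 mg/kg in this assay, at which 1 of the 2 values shown sits). Within the data shown here, no step between two measured compounds is available, so the series gives no measured direction to lean on.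

Compound 3, `CCCCCCCOc1ccc(CC[C@@](N)(CO)CCO)cc1`, is not yet measured. It differs from compound 2 by a group of 7 heavy atoms (4 carbon, 1 nitrogen, 2 oxygen; no ring) in place of a group of 7 heavy atoms (5 carbon, 1 nitrogen, 1 oxygen; no ring), on a saturated chain carbon, two bonds along the chain from an aromatic carbon.

Among the measured compounds shown here, for this change no measured step exists, so the expected step is set at no more than a modest one in this assay, leaning toward an effect at smaller amounts. The step from compound 2 to compound 3 is expected to be a 1.8-fold lower number from compound 2 to compound 3 (0.26 log units; within the scatter). Compound 3 is expected to give 1.5 mg/kg, within a range from 0.4 mg/kg to 6 mg/kg.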

Compound 3, dose for 50% inhibition: 0.017 mg/kg
Beside the measured number, compound 3's estimate is 88-fold (1.95 log units) above it; the whole stated range lies above it.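

In this assay, among these compounds, the exchange on a saturated chain carbon, two bonds along the chain from an aromatic carbon, gives a 160-fold lower number from compound 2 to compound 3 (2.20 log units; beyond the scatter), the first measured step, and it shows that this place responds strongly to a change of group. The group that enters has 2 oxygen, 3 hydrogen-bond donors and 1 defined stereocentre, where the group that leaves has 1 oxygen and 2 hydrogen-bond donors. No measured property bears on this step, so its origin stays unassigned.

Open, going by these compounds, is whether the extra oxygen or the defined stereocentre carries the step, since both change together here. Also open, on these data alone, is how the same place responds to other groups, such as a methoxy-bearing chain or a carboxylic acid.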